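Varying the Acyl Group on the Piperazine Amide

The compounds below may be only part of what the source reports. "The series", "measured", "known", "first", "only" and "open" are said of these compounds alone.

Compound 1 `CC(C)C(=O)N1C[C@@H](C)N(c2ncc3[nH]nc(-c4ccc(N5CCN[C@H](C)C5)nc4)c3n2)[C@@H](C)C1` gives 8 nM in an assay on Sf9 cells for inhibition of activin receptor type-1 (Homo sapiens), read by HTRF, with a stated time of 3 h, in the presence of a further agent that is not named here; on this read-out lower numbers stand for stronger inhibition and higher numbers for weaker inhibition. Among the three measured compounds its number is the second highest. Compound 3 `CC1CCCCN1c1ncc2[nH]nc(-c3ccc(N4CCN[C@H](C)C4)nc3)c2n1` gives 8.1 nM, which lies within the scatter of compound 1. Compound 2 `COC(=O)N1C[C@@H](C)N(c2ncc3[nH]nc(-c4ccc(N5CCN[C@H](C)C5)nc4)c3n2)[C@@H](C)C1` gives 0.85 nM. The step of a 9.4-fold lower number from compound 1 to compound 2 (0.97 log units; beyond the scatter) came from methoxy in place of isopropyl on the carbonyl carbon, a clearly lower number.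

Compound 4 `C[C@@H]1CN(c2ccc(-c3n[nH]c4cnc(N5[C@H](C)CN(C(=O)N(C)C)C[C@@H]5C)nc34)cn2)CCN1` has not yet been measured. It differs from compound 1 by dimethylamino in place of isopropyl on a carbonyl carbon. The measured step at this same carbonyl carbon is the only one that bears on it, and it pointed toward a lower number. A move in the same direction, perhaps somewhat smaller, is expected for dimethylamino in place of isopropyl. Compound 4 is therefore estimated to give 2.5 nM in this assay, with a range from 0.8 nM to 8 nM, an expected step of a 3.2-fold lower number from compound 1 to compound 4 (0.51 log units; beyond the scatter).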

Compound 4, half-maximal inhibitory concentration: 6.4 nM
For compound 4 the middle estimate is 2.6-fold (0.41 log units) below the measured one, and the stated range covers the measured number.
By their numbers in this assay, from the lowest: compound 2; then compounds 4, 1 and 3 (each within the scatter of the next).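

Putting dimethylamino in place of isopropyl on this carbonyl carbon gives a 1.3-fold lower number from compound 1 to compound 4 (0.10 log units; within the scatter) and so leaves the number in this assay essentially unchanged. Putting dimethylamino in place of methoxy gives a 7.5-fold higher number from compound 2 to compound 4 (0.88 log units; beyond the scatter) and shows that the lower number of compound 2 does not extend to every replacement for isopropyl, even one of the same heavy-atom count. No measurement shown here explains why methoxy and dimethylamino differ.

Going by these compounds, it remains open whether ethoxy or methylamino on the same carbonyl carbon would track methoxy or dimethylamino. It is also unclear whether the methoxy gain would hold on a different core.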